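This account rests on a few compounds, and the source may have more. Where it says the series, first, only, none or still open, it means among the compounds named here.

Measured compounds:
Compound 1 `CCCC(=O)C1=C(C)NC(=O)NC1c1ccoc1` gives 22% in an assay on membranes from HEK293 cells for displacement of a labelled ligand from adenosine receptor A2b (Homo sapiens), read by scintillation counting, with a stated time of 30 min, tested at 1 uM; a higher number here means more inhibition at the concentration tested (going by the name of the read-out), a lower number less inhibition.
Compound 2 `CCSC(=O)C1=C(C)NC(=O)NC1c1ccco1` gives 29% in this assay.

Compound 2 stands with compound 1 inside the scatter of repeated measurement, so no ordering of the two can be drawn. Compound 3 `CCSC(=O)C1=C(C)NC(=O)NC1c1ccoc1` is the same set of atoms joined differently: furan-3-yl in place of furan-2-yl on a saturated ring carbon. Within the data shown here, no step between measured compounds tells how this change acts here. Compound 1 already carries the furan-3-yl group at the same place and sits within the scatter of compound 2, so the expected step of a number 4 percentage points lower from compound 2 to compound 3 (within the scatter) is none beyond the scatter. Compound 3 is therefore expected to give about 25%, within 10% to 42%.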

Compound 3, a percentage reported as inhibition, at one concentration (the size of the read-out at that concentration, not a potency): 1%
The estimate for compound 3 lay 24 percentage points above the measured number, outside the stated range (below it).
By their numbers in this assay, from the lowest: compound 3; then compounds 1 and 2 (each within the scatter of the next).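

Moving the link of the furan ring alone, with the same atoms, counts in this assay: the change gives a number 28 percentage points lower from compound 2 to compound 3 (beyond the scatter). With furan-3-yl held in place, ethylsulfanyl in place of propyl on the carbonyl carbon also counts, giving a number 21 percentage points lower from compound 1 to compound 3 (beyond the scatter), so neither group can be read alone as harmless. Nothing shown gives a reason for either step. Going by these compounds, whether furan-2-yl would give the same step with propyl on the carbonyl carbon stays open. So does how a phenyl ring on the saturated ring carbon would read.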